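Chlorophenyl for difluorophenyl on the shared core

This account rests on a few compounds, and the source may have more. Where it says the series, first, only, none or still open, it means among the compounds named here.

Compound 1 `CCOC(=O)C1=Cc2ccccc2OC1(OCc1cc(-c2ccc(F)cc2F)no1)C(F)(F)F` carries a 2,4-difluorophenyl on the five-membered aromatic ring with 1 nitrogen and 1 oxygen. In a functional assay on A549 cells (Homo sapiens) for inhibition, read by MTT assay, with a stated time of 24 h (a lower number here means a stronger inhibitor, a higher number a weaker inhibitor), compound 1 gives > 150000 nM, which is a limit of the assay and not a number. Compound 2 `CCCCCCCCn1cc(COC2(C(F)(F)F)Oc3ccccc3C=C2C(=O)OCC)nn1` bears a heptyl on a saturated chain carbon bound to an aromatic nitrogen. In this assay compound 2 gives > 150000 nM, again only a limit. Compound 3 `CCOC(=O)C1=Cc2ccccc2OC1(OCc1cn(CC(=O)Nc2ccccc2Br)nn1)C(F)(F)F` has a (2-bromophenyl)carbamoyl in that place. In this assay compound 3 gives > 150000 nM, also a limit. For the measured compounds named here, the one step between measured compounds, a step that the two limits leave unreadable from compound 2 to compound 3, has no readable size, since both ends sit at the limit; the whole series so far is summarised by the limit of > 150000 nM in this assay, at which 3 of the 3 values shown sit.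

Compound 4 `CCOC(=O)C1=Cc2ccccc2OC1(OCc1cc(-c2ccc(Cl)cc2)no1)C(F)(F)F` differs from compound 1 by 4-chlorophenyl in place of 2,4-difluorophenyl on an aromatic carbon. Going by the values given here, no measured step touches this position, and no measured value gives a number to anchor a change. The expectation for compound 4 is thus that it stays where compound 1 stands, because compound 1 gives > 150000 nM. Compound 4 is expected at 250000 nM, in the range 100000 nM to 800000 nM. The step that the limit leaves unreadable from compound 1 to compound 4 is expected to be none beyond the scatter.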

Compound 4, half-maximal inhibitory concentration: 19100 nM
Compound 4: the middle estimate sits 13-fold (1.12 log units) above what was measured; the whole stated range lies above it.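

For the compounds shown here, changing this aromatic carbon's substituent is the first change to give a readable result: 4-chlorophenyl in place of 2,4-difluorophenyl gives an at least 7.8-fold lower number from compound 1 to compound 4 (0.89 log units; beyond the scatter) in this assay. Going by these compounds, compound 1 gives > 150000 nM, which is a limit of the assay and not a number, so the printed size of the step is a minimum and its true size stays unknown. Compound 4 is the only compound shown with a measured number, which makes the aryl group on the five-membered aromatic ring with 1 nitrogen and 1 oxygen the one place so far where the read-out comes off the limit: the limit of > 150000 nM in this assay, at which 3 of the 4 values shown sit.

The step from compound 1 to compound 4 removes two fluorines and adds one chlorine at once, so it cannot say whether the chlorine, the loss of the fluorines, or both account for the lower number; a 4-fluorophenyl or a plain phenyl on this carbon would separate these. Also open, on these data alone, is whether a 4-methoxyphenyl or a 4-aminophenyl here would go further in the same direction, and whether 4-chlorophenyl would have any such effect on the compounds that carry the other ring, such as compound 2 and compound 3.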